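The compounds below may be only part of what the source reports. "The series", "measured", "known", "first", "only" and "open" are said of these compounds alone.

Going by the values given here, compound 1 `COc1nc2ccc(Br)cc2cc1C(c1ccccc1)n1cc(-c2ccc(Br)cc2)nn1` gives 13.4% in an ADME assay on SK-OV-3 cells (Homo sapiens) for cytotoxicity, read by sulforhodamine B assay, with a stated time of 48 h, tested at 10 uM (a higher number here means more inhibition at the concentration tested (going by the name of the read-out), a lower number less inhibition), which places it second highest of the three numbers so far. Compound 3 `COc1nc2ccc(Br)cc2cc1C(c1ccccc1)n1cc(-c2ccccc2)nn1` stands nearest to it, with 13.7%, while compound 2 `CCCCCCCc1cn(C(c2ccccc2)c2cc3cc(Br)ccc3nc2OC)nn1` stands furthest, with 10.5%. All three lie within the scatter of one another: a number 0.3 percentage points higher from compound 1 to compound 3 (within the scatter), a number 2.9 percentage points lower from compound 1 to compound 2 (within the scatter) and a number 3.2 percentage points higher from compound 2 to compound 3 (within the scatter). Compound 4 `CCOC(=O)c1cn(C(c2ccccc2)c2cc3cc(Br)ccc3nc2OC)nn1` differs from compound 1 in one place: ethoxycarbonyl in place of 4-bromophenyl on an aromatic carbon. The steps that also swap the group on this aromatic carbon, from compound 1 to compound 2 and from compound 2 to compound 3, bear on this change, and both stayed within the scatter. No step beyond the scatter is therefore expected in this assay. Compound 4 is thus estimated at 12%, between 3% and 22%, an expected step of a number 1.4 percentage points lower from compound 1 to compound 4 (within the scatter).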

Compound 4, a percentage reported as inhibition, at one concentration (the size of the read-out at that concentration, not a potency): 2.01%
Compound 4: the middle estimate sits 10 percentage points above what was measured, and the stated range ends above it.
By their numbers in this assay, from the lowest: compounds 4, 2, 1 and 3 (each within the scatter of the next, the first and the last beyond it).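

In this assay, going by these compounds alone, the group on this aromatic carbon can move the number after all: ethoxycarbonyl in place of 4-bromophenyl gives a number 11.4 percentage points lower from compound 1 to compound 4 (beyond the scatter) and in place of phenyl gives a number 11.7 percentage points lower from compound 3 to compound 4 (beyond the scatter) as the first steps beyond the scatter at this position. In place of heptyl it gives a number 8.5 percentage points lower from compound 2 to compound 4 (within the scatter) and so stands apart only from the two ring-bearing groups, not from the chain. Nothing available gives a reason for this. As far as these compounds go, whether a carboxylic acid or an amide on this carbon would give a number as low as that of compound 4 stays open, as does whether the carbonyl or the ethyl part matters.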